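A Small Substituent Change Traced from Compound 1

The compounds below may be only part of what the source reports. "The series", "measured", "known", "first", "only" and "open" are said of these compounds alone.

Among the measured compounds shown here, compound 1 `CN(C)C/C=C(/c1ccccc1)c1cccnc1` is the one member of this set with a number rather than a limit. In an in vivo functional assay on the whole organism (brain) for inhibition of Norepinephrine transporter (Rattus norvegicus) (a higher number here means that more compound is needed for the effect, a lower number that less compound is needed), compound 1 gives 107 umol/kg. Compound 2 `CN(C)C/C=C(/c1ccc(C(F)(F)F)cc1)c1cccnc1` carries trifluoromethyl in place of hydrogen on an aromatic carbon; in this assay compound 2 reaches only the limit > 101 umol/kg. That step is a step that the limit leaves unreadable from compound 1 to compound 2. Compound 3 `COc1ccc(/C(=C/CN(C)C)c2cccnc2)cc1` carries methoxy in place of hydrogen on an aromatic carbon; in this assay compound 3 also stops at the limit > 112 umol/kg. The step is an at least 1.0-fold higher number from compound 1 to compound 3 (0.01 log units; that floor lies within the scatter), and the step that the two limits leave unreadable from compound 2 to compound 3 is likewise unreadable.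

Compound 4 `CN(C)C/C=C(\c1cccnc1)c1cccc(F)c1` differs from compound 1 by fluoro in place of hydrogen on an aromatic carbon. Both measured steps from compound 1 replace hydrogen on an aromatic carbon with a new group and both run to a limit, as the limit of > 101 umol/kg in this assay, at which 1 of the 3 values shown sits, and the limit of > 112 umol/kg in this assay, at which 1 of the 3 values shown sits, show, so they give a direction but no size. The step from compound 1 to compound 4 is therefore expected to go toward a higher number in this assay, by a 1.4-fold higher number from compound 1 to compound 4 (0.15 log units; within the scatter), with a real chance that only a limit is recorded. Compound 4 is expected at 150 umol/kg, within 60 umol/kg to 400 umol/kg.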

Compound 4, dose for half-maximal effect: 33 umol/kg
Estimate against measurement, compound 4: 4.5-fold (0.66 log units) above; the whole stated range lies above it.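

Among the compounds shown here, with compound 4, the set gains its first substituent on the six-membered aromatic ring of carbon only that gives a number rather than a limit in this assay, and the result is a 3.2-fold lower number from compound 1 to compound 4 (0.51 log units; beyond the scatter), so less compound is needed for the effect. This shows that replacing hydrogen with a new group on an aromatic carbon need not leave the number unchanged or push it upward: fluoro, a single heavy atom meta to a large group, moves it down by a step beyond the scatter, whereas the remaining steps among compound 1, compound 2 and compound 3 run to limits and cannot be read for size. Nothing given here identifies a cause for this step.

The compounds shown leave open whether the lower number belongs to fluoro itself or to the place it occupies, since no other group sits at that same place on the core of compound 1. They also leave open how chloro, methyl, nitrile or an amine would read there, and whether a second fluoro would carry the change further.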